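The source may hold more compounds than are shown below. What is called first, only, known or untested is meant among the compounds shown, and "the series" means these compounds.

Measured so far in an assay on SH-SY5Y cells for inhibition of Voltage-dependent L-type calcium channel subunit alpha-1D (Homo sapiens), read by calcium flux, with a stated time of 15 min; on this read-out lower numbers stand for stronger inhibition and higher numbers for weaker inhibition:
- compound 1 `CCOC(=O)C1=C(C)NC(c2ccc(Cl)cc2)=CC1c1cccc(OC)c1`: 15100 nM
- compound 2 `CCOC(=O)C1=C(C)NC(c2ccc(C)cc2)=CC1c1ccccc1[N+](=O)[O-]`: 44100 nM

Compound 2 stands at the higher of the two numbers in this assay, and the gap down to compound 1 lies beyond the scatter. Compound 3 `CCOC(=O)C1=C(C)NC(c2ccc(Cl)cc2)=CC1c1ccccc1[N+](=O)[O-]` differs from compound 2 by chloro in place of methyl on an aromatic carbon. Among the compounds with values here, no measured pair shows this same change, so its effect on this assay is unknown here; a step within the scatter is expected, with no clear direction. Compound 3 is therefore expected to give about 30000 nM, within 12000 nM to 75000 nM, which is an expected step of a 1.5-fold lower number from compound 2 to compound 3 (0.17 log units; within the scatter).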

Compound 3, half-maximal inhibitory concentration: 57100 nM
The estimate for compound 3 lay 1.9-fold (0.28 log units) below the measured number, within the range that was stated.
By their numbers in this assay, from the lowest: compound 1; then compounds 2 and 3 (each within the scatter of the next).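

In this assay chloro in place of methyl, para to a large group, gives a 1.3-fold higher number from compound 2 to compound 3 (0.11 log units; within the scatter) and so the two groups cannot be told apart here while the 2-nitrophenyl group stays fixed. With chloro kept, 2-nitrophenyl in place of 3-methoxyphenyl gives a 3.8-fold higher number from compound 1 to compound 3 (0.58 log units; beyond the scatter) and this is the only change shown that clears the scatter. Nothing measured here explains either step.

As far as these compounds go, whether an amine or a carboxylic acid at this position would move the number remains open. So does whether methyl and chloro stay alike alongside 3-methoxyphenyl.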